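A few compounds are considered here, and "the series" means these few. Any claim that something is new, unique, unknown or untested is made for them only; others in the source may bear on it.

Two aryl triazenes on a shared core have been measured in a functional assay on L1210 cells (Mus musculus) for antiproliferative activity; on this read-out lower numbers stand for lower potency and higher numbers for higher potency (the scale is a negative logarithm). Compound 1 `CN(C)/N=N/c1cccc(C(N)=O)c1` carries a carbamoyl group on its aromatic ring, and in this assay compound 1 gives 3.8. Compound 2 `CN(C)/N=N/c1ccccc1Cl` carries a chloro group instead, and in this assay compound 2 gives 3.26. For the measured compounds named here, compound 2 stands lowest of the two numbers known so far; its nearest neighbour is compound 1, which lies higher by a gap beyond the usual scatter.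

The next compound, compound 3 `CN(C)/N=N/c1ccccc1C(N)=O`, differs from compound 2 in one place: carbamoyl in place of chloro on an aromatic carbon. The carbamoyl group of compound 3 sits on an aromatic carbon of a six-membered aromatic ring of carbon only, ortho to a group of 5 heavy atoms. Going by the values given here, no step between measured compounds in this assay is available, so the size of the move is open. The expected step is a number 0.34 log units higher from compound 2 to compound 3 (beyond the scatter), upward and beyond the scatter, because compound 1 with its own carbamoyl group gives 3.8. Compound 3 is therefore estimated at 3.6 in this assay, with a range from 3.1 to 4.1.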

Compound 3, logarithm of the reciprocal of the active concentration, log(1/C): 3.31
Beside the measured number, compound 3's estimate is 0.29 log units above it; measured number inside the range.
By their numbers in this assay, from the lowest: compounds 2 and 3 (each within the scatter of the next); then compound 1.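

At this place, on an aromatic carbon ortho to a group of 5 heavy atoms, carbamoyl in place of chloro gives a number 0.05 log units higher from compound 2 to compound 3 (within the scatter) in this assay. Although carbamoyl brings more heavy atoms than chloro, plus a hydrogen-bond donor and a hydrogen-bond acceptor, this read-out does not separate the two groups here. A carbamoyl group on the ring is therefore not enough by itself to give the higher number of compound 1 (3.8), and nothing measured here explains this result.

The compounds shown leave open whether other groups at this place, such as an amine, a carboxylic acid or a longer chain, would also stay within the scatter of chloro and carbamoyl or would stand clearly apart from them. They also leave open how chloro would read at the place that the carbamoyl group holds in compound 1, so the contribution of the group's position cannot yet be separated from that of its identity.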